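Swapping 3-chlorophenyl for 5-bromopyridin-3-yl

The compounds below may be only part of what the source reports. "The series", "measured", "known", "first", "only" and "open" are said of these compounds alone.

Compound 1 (`Nc1ccccc1NC(=O)c1ccc(NC(=S)NCc2ccc(Cl)nc2)cc1`), compound 2 (`Nc1ccccc1NC(=O)c1ccc(NC(=S)NCc2cccnc2)cc1`) and compound 3 (`Nc1ccccc1NC(=O)c1ccc(NC(=S)NCc2cccc(Cl)c2)cc1`) share one core and differ only in the ring at the end of a side chain. In a functional assay on MDA-MB-231 cells (Homo sapiens) for cytotoxicity, read by MTT assay, with a stated time of 72 h (a lower number here means a stronger inhibitor, a higher number a weaker inhibitor), compound 1 gives 42000 nM and compound 3 gives 92000 nM, the higher of the two numbers and so the weaker result. For compound 2 the result stands as "not determined" (no result reported).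

Compound 4 (`Nc1ccccc1NC(=O)c1ccc(NC(=S)NCc2cncc(Br)c2)cc1`) has not yet been measured. It carries 5-bromopyridin-3-yl in place of 3-chlorophenyl on a saturated chain carbon bound to an amide-type nitrogen.

Within the data shown here, only one measured step bears on this change: a 2.2-fold higher number from compound 1 to compound 3 (0.34 log units; beyond the scatter), where 3-chlorophenyl replaced 6-chloropyridin-3-yl. Read in reverse, that modest step hints that a pyridinyl group may bring the number down. However, no measured compound carries bromine, so the hint is weak. A small drop is therefore expected in this assay, estimated as a 1.7-fold lower number from compound 3 to compound 4 (0.22 log units; within the scatter), and it may not clear the scatter. The estimated value for compound 4 is 55000 nM, with an expected range of 25000 nM to 110000 nM.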

Compound 4, half-maximal inhibitory concentration: 39000 nM
Compound 4: the middle estimate sits 1.4-fold (0.15 log units) above what was measured; the measured number falls inside the stated range.
By their numbers in this assay, from the lowest: compounds 4 and 1 (each within the scatter of the next); then compound 3.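

In this assay, the change at this position gives a 2.4-fold lower number from compound 3 to compound 4 (0.37 log units; beyond the scatter), so the bromine-bearing pyridinyl ring joins the 6-chloropyridin-3-yl ring of compound 1 on the lower side of compound 3. The comparison of the two pyridinyl rings gives a 1.1-fold lower number from compound 1 to compound 4 (0.03 log units; within the scatter), which leaves compound 1 and compound 4 level within the scatter, even though they carry different halogens on their rings. Among these three compounds, the two with a ring nitrogen thus share the lower numbers, but no measurement available here explains this link.

From the compounds shown here alone, compound 2 has no reported number, so what the pyridin-3-yl ring does without any halogen stays open. Also unknown is how an amine or a methoxy group on the ring, or a longer chain leading to it, would compare.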